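A few compounds are considered here, and "the series" means these few. Any claim that something is new, unique, unknown or untested is made for them only; others in the source may bear on it.

Compound 1 `NS(=O)(=O)c1ccc(C(=O)NNC(=O)c2ccccc2)cc1` is the parent of the pair under review. In an assay on cells for inhibition of Amine oxidase [flavin-containing] B (Homo sapiens), read by fluorescence and spectrophotometry, using microsomes, with a stated time of 20 min (on this read-out lower numbers stand for stronger inhibition and higher numbers for weaker inhibition), compound 1 gives only a limit of the assay, > 100000 nM; this is the limit of > 100000 nM in this assay, at which 1 of the 3 values shown sits. Compound 2 `N#Cc1ccc(-c2nnc(-c3ccc(S(N)(=O)=O)cc3)o2)cc1` and compound 3 `NS(=O)(=O)c1ccc(-c2nnc(-c3ccc(Cl)cc3)o2)cc1` share a different core. Compound 2 gives 318 nM and compound 3 gives 48 nM. Among the compounds with values here, the single measured step, a 6.6-fold lower number from compound 2 to compound 3 (0.82 log units; beyond the scatter), puts the chloro analogue ahead of the nitrile. Compound 4 `NS(=O)(=O)c1ccc(C(=O)NNC(=O)c2ccc(Cl)cc2)cc1` differs from compound 1 by chloro in place of hydrogen on an aromatic carbon. That change replaces hydrogen, not cyano, so the measured step bears on it only loosely, and compound 1 starts at a limit. A value near the limit is therefore expected for compound 4, the step that the limit leaves unreadable from compound 1 to compound 4 being small and uncertain. Compound 4 is estimated at 150000 nM, range 20000 nM to 1000000 nM.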

Compound 4, half-maximal inhibitory concentration: 11700 nM
Beside the measured number, compound 4's estimate is 13-fold (1.11 log units) above it, and the stated range ends above it.
By their numbers in this assay, from the lowest: compound 3; then compound 2; then compound 4. At a limit, above all of these: compound 1.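

Phenyl to 4-chlorophenyl on the core of compound 1 gives an at least 8.5-fold lower number from compound 1 to compound 4 (0.93 log units; beyond the scatter) in this assay and yields a measurable value on this core. Chloro had earlier been read only in place of cyano on a different core; here it is read in place of hydrogen. The step is only a lower bound because compound 1 stands at a limit: the limit of > 100000 nM in this assay, at which 1 of the 4 values shown sits.

On these data alone, whether bromo or methoxy at this place would match chloro remains open. Also open, as far as these compounds go, is how chloro compares with hydrogen on the core of compound 3.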